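The source may report more compounds than this note shows. Statements on the series, on what has been measured and on what is new or still open speak of the compounds shown alone.

Series notes. The shared core of compound 1 `Cn1ccc2c(Oc3ccc(NC(=O)c4cc5cccnc5n(-c5ccccc5)c4=O)cc3)ccnc21` carries a phenyl on an aromatic nitrogen; in a functional assay on HT-29 cells (Homo sapiens) for antiproliferative activity, read by MTT assay, with a stated time of 72 h (a higher number here means a weaker inhibitor, a lower number a stronger inhibitor), compound 1 gives 620 nM. Compound 2 `COc1ccc(-n2c(=O)c(C(=O)Nc3ccc(Oc4ccnc5c4ccn5C)cc3)cc3cccnc32)cc1` gives 2050 nM in this assay, and compound 3 `Cn1ccc2c(Oc3ccc(NC(=O)c4cc5cccnc5n(-c5ccc(Br)cc5F)c4=O)cc3)ccnc21` gives 2580 nM. Compound 3 stands highest of the three numbers; its gap to compound 2 is within the scatter, while the step of a 4.2-fold higher number from compound 1 to compound 3 (0.62 log units; beyond the scatter) is beyond it. Compound 4 `Cn1ccc2c(Oc3ccc(NC(=O)c4cc5cccnc5n(-c5ccc(C(F)(F)F)cc5Cl)c4=O)cc3)ccnc21` differs from compound 3 by 2-chloro-4-(trifluoromethyl)phenyl in place of 4-bromo-2-fluorophenyl on an aromatic nitrogen. For the measured compounds named here, two measured steps bear on this change: a 4.2-fold higher number from compound 1 to compound 3 (0.62 log units; beyond the scatter) shows that going from phenyl to the 4-bromo-2-fluorophenyl ring raised the number, whereas a 1.3-fold higher number from compound 2 to compound 3 (0.10 log units; within the scatter) shows that exchanging one substituted ring for another left the number about where it was. The change to compound 4 is of the second kind, a swap between two substituted rings, so no step beyond the scatter is expected in this assay, with at most a lean toward a somewhat higher number. For compound 4 the expected step is a 1.4-fold higher number from compound 3 to compound 4 (0.13 log units; within the scatter). Compound 4 is estimated to give 3500 nM in this assay, within 1500 nM to 8500 nM.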

Compound 4, half-maximal inhibitory concentration: 6050 nM
Estimate against measurement, compound 4: 1.7-fold (0.24 log units) below, and the stated range covers the measured number.
By their numbers in this assay, from the lowest: compound 1; then compounds 2 and 3 (each within the scatter of the next); then compound 4.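

In this assay a swap between two substituted rings on the aromatic nitrogen need not leave the number in place: a 2.3-fold higher number from compound 3 to compound 4 (0.37 log units; beyond the scatter) lies beyond the scatter, whereas a 1.3-fold higher number from compound 2 to compound 3 (0.10 log units; within the scatter) stays within it. The further steps a 3.0-fold higher number from compound 2 to compound 4 (0.47 log units; beyond the scatter) and a 9.8-fold higher number from compound 1 to compound 4 (0.99 log units; beyond the scatter) put 2-chloro-4-(trifluoromethyl)phenyl highest of the four rings, and all three substituted rings stand above the phenyl of compound 1, with no compound shown against that order. Nothing available gives a reason for these steps.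

From the compounds shown here alone, whether a ring carrying an amine or a carboxylic acid would go below compound 1 at 620 nM remains open. Also open, going by these compounds, is which part of the entering ring, the chlorine or the trifluoromethyl, carries the step; the two appear here only together.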